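Replacing the piperazine tail of compound 2

The source may hold more compounds than are shown below. What is called first, only, known or untested is meant among the compounds shown, and "the series" means these compounds.

Values in a functional assay on HCT-116 cells (Homo sapiens) for inhibition; a lower number here means that less compound is needed, a higher number that more compound is needed for the effect
- compound 1 (`COc1cc(N2CCN(C(=O)N3CCN(C)CC3)CC2)ccc1Nc1nc(NC2CCCCC2)c2nc[nH]c2n1`): 18 nM
- compound 2 (`COc1cc(N2CCN(CC3CCOC3)CC2)ccc1Nc1nc(NC2CCCCC2)c2nc[nH]c2n1`): 170 nM

Of the two numbers, the higher belongs to compound 2 at 170 nM. For the measured compounds named here, the sole measured step is a 9.4-fold higher number from compound 1 to compound 2 (0.98 log units; beyond the scatter), where (oxolan-3-yl)methyl takes the place of (4-methylpiperazin-1-yl)carbonyl on an amine nitrogen in a ring.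

Compound 3 (`CCN(CC)CC1CCN(c2ccc(Nc3nc(NC4CCCCC4)c4nc[nH]c4n3)c(OC)c2)CC1`) has not yet been measured. It differs from compound 2 as follows: 4-((diethylamino)methyl)piperidin-1-yl in place of 4-((oxolan-3-yl)methyl)piperazin-1-yl on an aromatic carbon. In short, 4-((diethylamino)methyl)piperidin-1-yl stands in place of 4-((oxolan-3-yl)methyl)piperazin-1-yl on an aromatic carbon.

The evidence is thin. Going by the values given here, the change in compound 2 falls on the same substituent that moved the number in a 9.4-fold higher number from compound 1 to compound 2 (0.98 log units; beyond the scatter), but no measured step covers the entering group. A step no larger than that one is expected, tentatively towards a lower number, and a result within the scatter would not be surprising. The estimated step is a 2.1-fold lower number from compound 2 to compound 3 (0.33 log units; beyond the scatter). For compound 3 the expected value in this assay is 80 nM, with an estimated range from 20 nM to 300 nM.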

Compound 3, half-maximal effective concentration: 55 nM
Compound 3: middle estimate off by 1.5-fold (0.16 log units), on the high side; the range from low to high includes it.
By their numbers in this assay, from the lowest: compound 1; then compound 3; then compound 2.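

Notes on the tail position: in this assay, the group on this aromatic carbon, para to a large group and meta to a methoxy group, can be exchanged as a whole, and 4-((diethylamino)methyl)piperidin-1-yl in place of 4-((oxolan-3-yl)methyl)piperazin-1-yl gives a 3.1-fold lower number from compound 2 to compound 3 (0.49 log units; beyond the scatter). Unlike the earlier step, which kept the piperazine and changed only the group on its ring nitrogen, this change replaces the ring and its side chain together at an equal heavy-atom count, so the number moves beyond the scatter without any change in the size of the group by that count, while compound 3 at 55 nM still stands above compound 1 at 18 nM. No measurement available here accounts for the shift between compound 2 and compound 3.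

The ring and the side chain changed in a single step, so their separate contributions remain unresolved; 4-((diethylamino)methyl)piperazin-1-yl would divide the step between them. Also open, from the compounds shown here alone, is how far the number depends on the terminal amine, which a pyrrolidine, a morpholine or a dimethylamino group in place of the diethylamino group on the same piperidine would test.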